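The source may hold more compounds than are shown below. What is called first, only, known or untested is meant among the compounds shown, and "the series" means these compounds.

Among the measured compounds shown here, in a physicochemical assay for lipophilicity (on this read-out lower numbers stand for lower lipophilicity and higher numbers for higher lipophilicity), three compounds have numbers so far. Compound 1 (`CCCCCCCCS(=O)(=O)c1ccc(O)c(C(=O)Nc2ccc(C(F)(F)F)cc2)c1`) gives 5.26 and compound 2 (`CCCCCCCCCCS(=O)(=O)c1ccc(O)c(C(=O)Nc2ccc(Br)cc2)c1`) gives 5.36 on this read-out. Compound 3 (`CCCCCCCCCCCCS(=O)(=O)c1ccc(O)c(C(=O)Nc2ccc(C(F)(F)F)cc2)c1`) stands highest of the three at 6.2 and lies clearly apart from both others. Compound 4 (`CCCCCCCCCCS(=O)(=O)c1ccc(O)c(C(=O)Nc2ccc(C(F)(F)F)cc2)c1`) has not yet been measured.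

The change from compound 3 to compound 4 is counted as hydrogen in place of ethyl on a saturated chain carbon, ten or more bonds along the chain from a sulfonyl sulfur and reads in words as hydrogen in place of ethyl on a saturated chain carbon, ten or more bonds along the chain from a sulfonyl sulfur. The chain simply ends up shorter, while the rest of the molecule stays the same.

For the measured compounds named here, one measured step bears on this. With butyl in place of hydrogen on a saturated chain carbon, eight bonds along the chain from a sulfonyl sulfur, the numbers show a number 0.94 log units higher from compound 1 to compound 3 (beyond the scatter) and that single step is the whole basis for expecting compound 4, which loses ethyl from the chain, to come out lower by a smaller step. The expected move is a number 0.47 log units lower from compound 3 to compound 4 (beyond the scatter) in this assay and should lie beyond the scatter. For compound 4 the estimate is 5.73 with an expected range from 5.4 to 6 on this scale.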

Compound 4, distribution coefficient: 6.34
Estimate against measurement, compound 4: 0.61 log units below; the whole stated range lies below it.
By their numbers in this assay, from the lowest: compounds 1 and 2 (each within the scatter of the next); then compounds 3 and 4 (each within the scatter of the next).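

In this assay, hydrogen in place of ethyl on a saturated chain carbon, ten or more bonds along the chain from a sulfonyl sulfur, gives a number 0.14 log units higher from compound 3 to compound 4 (within the scatter), so the two chain lengths cannot be told apart on this read-out. The earlier a number 0.94 log units higher from compound 1 to compound 3 (beyond the scatter) looked like a gain spread along the whole added stretch of chain, yet a number 1.08 log units higher from compound 1 to compound 4 (beyond the scatter) shows that the ethyl added eight bonds along the chain already accounts for the clear difference among these three compounds, and the further ethyl adds nothing that can be read. With the chain held the same, trifluoromethyl in place of bromo on an aromatic carbon gives a number 0.98 log units higher from compound 2 to compound 4 (beyond the scatter), so the group at the other end of the molecule also moves this number clearly. No measurement at hand explains why the numbers behave this way.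

On these data alone, whether the numbers stay level with a longer chain, or shift once a carboxylic acid or an amine sits at the chain end, remains open. Equally open, as far as these compounds go, is how a chloro or nitrile group would compare with trifluoromethyl and bromo on that aromatic carbon.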